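A few compounds are considered here, and "the series" means these few. Any claim that something is new, unique, unknown or untested is made for them only; others in the source may bear on it.

Measured so far in a functional assay on DU-145 cells (Homo sapiens) for cytotoxicity, read by MTT assay; a lower number here means a stronger inhibitor, a higher number a weaker inhibitor:
compound 1, `COC(C)CO[C@H](CC=C(C)C)C1=CC(=O)c2c(O)ccc(O)c2C1=O`: 16600 nM
compound 2, `CCC(CO[C@H](CC=C(C)C)C1=CC(=O)c2c(O)ccc(O)c2C1=O)OC(C)=O`: 25400 nM
compound 3, `CCC(O)(CC)CC(=O)O[C@H](CC=C(C)C)C1=CC(=O)c2c(O)ccc(O)c2C1=O`: 67000 nM

Compound 1 gives the lowest number of the three. Its nearest neighbour is compound 2: a 1.5-fold higher number from compound 1 to compound 2 (0.18 log units; within the scatter). The widest gap is to compound 3: a 4.0-fold higher number from compound 1 to compound 3 (0.61 log units; beyond the scatter). Between the two esters the difference is a 2.6-fold higher number from compound 2 to compound 3 (0.42 log units; beyond the scatter).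

Compound 4, `CC(=O)OC(C)CO[C@H](CC=C(C)C)C1=CC(=O)c2c(O)ccc(O)c2C1=O`, awaits measurement. Against compound 1 the change is acetyl in place of methyl on an oxygen on a saturated carbon, read one bond further out as methoxy to acetoxy.

For the measured compounds named here, two measured steps bear on this. The step from compound 1 to compound 2 likewise turns a methoxy into an acetoxy arrangement on the side chain, and the number moved only a 1.5-fold higher number from compound 1 to compound 2 (0.18 log units; within the scatter). The step from compound 1 to compound 3 also introduces a carbonyl on an oxygen on a saturated carbon, and there the number moved a 4.0-fold higher number from compound 1 to compound 3 (0.61 log units; beyond the scatter). Both point the same way, toward a higher number; the closer analogy is the smaller one. The expected step is therefore a 1.3-fold higher number from compound 1 to compound 4 (0.12 log units; within the scatter), a small rise that may not clear the scatter.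

For compound 4 the estimate in this assay is 22000 nM, between 11000 nM and 45000 nM.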

Compound 4, half-maximal inhibitory concentration: 16600 nM
For compound 4 the middle estimate is 1.3-fold (0.12 log units) above the measured one, within the range that was stated.
By their numbers in this assay, from the lowest: compounds 1, 4 and 2 (each within the scatter of the next); then compound 3.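

In this assay, acetyl in place of methyl on an oxygen on a saturated carbon gives no change at the digits printed from compound 1 to compound 4 (within the scatter); this isolates methoxy to acetoxy as a single change, whereas the earlier step from compound 1 to compound 2 also altered the chain. Hydrogen in place of methyl on a saturated chain carbon, two bonds along the chain from an oxygen next to a carbonyl group, gives a 1.5-fold lower number from compound 2 to compound 4 (0.18 log units; within the scatter), so this chain difference also does not separate the two acetoxy compounds. With 2-acetoxypropyl in place of (2-ethyl-2-hydroxybutyl)carbonyl on an oxygen on a saturated carbon, the result is a 4.0-fold lower number from compound 3 to compound 4 (0.61 log units; beyond the scatter), leaving compounds 1, 2 and 4 within the scatter of one another and compound 3 alone at a higher number.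

No supporting measurement accounts for the separation of compound 3 from the other three compounds. As far as these compounds go, it remains open whether an amine or a carboxylic acid on this side chain, or a longer chain in place of the acetyl, would stay within the scatter of compound 4 or move as far as compound 3 does.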